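From Methoxy to Acetoxy: Compound 3 Becomes Compound 4

The source may hold more compounds than are shown below. What is called first, only, known or untested is meant among the compounds shown, and "the series" means these compounds.

In an ADME assay on HepG2 2.2.15 cells (Homo sapiens) for cytotoxicity (a higher number here means that more compound is tolerated, a lower number that less compound is tolerated), compound 1 `O=c1[nH]c2ccc(Cl)cc2c(-c2ccccc2Cl)c1CCO` gives 380000 nM as the top number, compound 2 `CCCC(=O)OCCc1c(-c2ccccc2Cl)c2cc(Cl)ccc2[nH]c1=O` gives 52000 nM and compound 3 `COCC(=O)OCCc1c(-c2ccccc2Cl)c2cc(Cl)ccc2[nH]c1=O` gives 74000 nM on the same scale. Compound 3 thus sits well under compound 1 and within the scatter of compound 2. Compound 4 `CC(=O)OCC(=O)OCCc1c(-c2ccccc2Cl)c2cc(Cl)ccc2[nH]c1=O` has acetyl in place of methyl on an oxygen on a saturated carbon, with acetyl in place of methyl on an oxygen on a saturated carbon as the counted change. The nearest comparison is a 1.4-fold higher number from compound 2 to compound 3 (0.15 log units; within the scatter) for a change within the same group, and it lies within the scatter, while a 7.3-fold lower number from compound 1 to compound 2 (0.86 log units; beyond the scatter) and a 5.1-fold lower number from compound 1 to compound 3 (0.71 log units; beyond the scatter) are modest steps for replacing a hydrogen on the oxygen. No step beyond the scatter is expected, and the estimated 1.1-fold lower number from compound 3 to compound 4 (0.06 log units; within the scatter) stays small. Compound 4 is estimated at 65000 nM within a range of 28000 nM to 150000 nM on this reading.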

Compound 4, half-maximal cytotoxic concentration: 100000 nM
Compound 4: middle estimate off by 1.5-fold (0.19 log units), on the low side; measured number inside the range.
By their numbers in this assay, from the lowest: compounds 2, 3 and 4 (each within the scatter of the next); then compound 1.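

In this assay acetyl in place of methyl on the oxygen gives (a 1.4-fold higher number from compound 3 to compound 4 (0.13 log units; within the scatter)) and acetoxy in place of ethyl gives (a 1.9-fold higher number from compound 2 to compound 4 (0.28 log units; within the scatter)), so the longer side chain with its added carbonyl leaves compound 2, compound 3 and compound 4 within the scatter of one another. Capping the hydrogen of compound 1 with (acetoxymethyl)carbonyl still gives (a 3.8-fold lower number from compound 1 to compound 4 (0.58 log units; beyond the scatter)), the same direction as the two earlier replacements of that hydrogen. Nothing available explains these numbers.
As far as these compounds go, whether an amine or a carboxylic acid in place of the acetoxy would also stay within that scatter remains open.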